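The source may report more compounds than this note shows. Statements on the series, on what has been measured and on what is new or still open speak of the compounds shown alone.

Measured so far:
compound 1 `CCCN(CCC)S(=O)(=O)c1ccc(S(=O)(=O)N2CCC[C@@H](C(=O)OCC)C2)cc1` — 600 nM
compound 2 `CCN(CC)S(=O)(=O)c1ccc(S(=O)(=O)N2CCC[C@@H](C(=O)NC3CN(C(=O)C4CC4)C3)C2)cc1` — 3100 nM

Both were run in a functional assay on MIA PaCa-2 cells (Homo sapiens) for inhibition, read by MTT assay, with a stated time of 3 days; on this read-out lower numbers stand for stronger inhibition and higher numbers for weaker inhibition. Compound 1 gives 600 nM, and compound 2 gives 3100 nM, the higher of the two numbers, with the gap to compound 1 beyond the scatter. These two differ in more than one place, so nothing here is tied to a single change. Compound 3 `CCN(CC)S(=O)(=O)c1ccc(S(=O)(=O)N2CCC[C@@H](C(=O)NC3CN(C(=O)OC(C)(C)C)C3)C2)cc1` is not yet measured; it differs from compound 2 by tert-butoxy in place of cyclopropyl on a carbonyl carbon. Among the compounds with values here, no measured pair isolates this change, so the expected step is a 1.0-fold lower number from compound 2 to compound 3 (0.01 log units; within the scatter), not beyond the scatter. Compound 3 is estimated at 3000 nM, with a range from 1200 nM to 7500 nM.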

Compound 3, half-maximal inhibitory concentration: 100 nM
Compound 3: middle estimate off by 30-fold (1.48 log units), on the high side; measured number outside the range, below it.
By their numbers in this assay, from the lowest: compound 3; then compound 1; then compound 2.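

Within the data shown here, the carbonyl carbon bound to the ring amide-type nitrogen is a sensitive position: in this assay tert-butoxy in place of cyclopropyl gives a 31-fold lower number from compound 2 to compound 3 (1.49 log units; beyond the scatter) and this is the first step tied to a single change. The earlier pair differed in more than one place and could show nothing of the kind. Nothing measured on hand accounts for this step. Still open, as far as these compounds go, is whether the oxygen or the tert-butyl part of tert-butoxy matters: a tert-butyl group or a methoxy group on the same carbonyl carbon would separate the two.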